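The source may report more compounds than this note shows. Statements on the series, on what has been measured and on what is new or still open speak of the compounds shown alone.

Two compounds of this series have been run in an ADME assay on HCT-116 cells (Homo sapiens) for cytotoxicity, read by MTT assay, with a stated time of 72 h; on this read-out higher numbers stand for weaker inhibition and lower numbers for stronger inhibition. Compound 1 `Cc1ccc(NC(=O)c2cccc(/C=C3\CC(=O)N(c4ccccc4)C3=O)c2)cc1` carries a phenyl on the amide-type nitrogen in the ring. In this assay compound 1 reaches only the limit > 100000 nM, which is a limit of the assay and not a number. Compound 2 `CCCCCN1C(=O)C/C(=C\c2cccc(C(=O)Nc3ccc(C)cc3)c2)C1=O` carries a pentyl on that nitrogen instead. In this assay compound 2 likewise reaches only the limit > 100000 nM. The step that the two limits leave unreadable from compound 1 to compound 2 is therefore unreadable in size. Compound 2 thus stands at the limit, as the evidence the limit of > 100000 nM in this assay, at which 2 of the 2 values shown sit, shows, and no measured number anchors it.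

Compound 3 `CCCCCN1C(=O)C/C(=C\c2cccc(C(=O)Nc3cccc(F)c3)c2)C1=O` differs from compound 2 by 3-fluorophenyl in place of 4-methylphenyl on an amide-type nitrogen. Going by the values given here, no measured step touches this amide-type nitrogen, and the one measured step, between compound 1 and compound 2, gives no readable size. The expectation is therefore for no change beyond the scatter that could be read, with compound 3 expected to sit at or near the limit again.

Compound 3 is estimated at 100000 nM, within a range from 30000 nM to 300000 nM. This expectation corresponds to the step of a number no higher from compound 2 to compound 3 (the limit leaves the size open).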

Compound 3, half-maximal inhibitory concentration: > 100000 nM
Compound 3 was reported as a limit; the forecaster's own chance of this, stated with the estimate: 75%; the middle value lies on the limit itself.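

In this assay compound 3 gives > 100000 nM, which is a limit of the assay and not a number. With compound 2 also reported only as a limit, no step can be read between compound 2 and compound 3. The compounds shown leave open whether any change on either amide-type nitrogen moves the read-out, as all of them sit at one limit: the limit of > 100000 nM in this assay, at which 3 of the 3 values shown sit.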